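This account rests on a few compounds, and the source may have more. Where it says the series, first, only, none or still open, it means among the compounds named here.

In an ADME assay on the whole organism (Rattus norvegicus) for pharmacokinetics, using cassette dosing, at a dose of 1 mg/kg by the oral route (a lower number here means that a smaller share of the oral dose reaches the circulation, a higher number that a larger share of the oral dose reaches the circulation), compound 1 `CC(C)Oc1ccc(/N=c2\[nH]c(=O)n(C[C@@H](C)C(=O)O)c(=O)n2Cc2ccc(Cl)cc2)cc1Cl` gives 108% and compound 2 `Cc1ccc(Cn2c(=O)n(C[C@H](C)C(=O)O)c(=O)[nH]/c2=N\c2ccc(OC(C)C)c(Cl)c2)cc1` gives 73.1% as the lower of the two numbers, a gap beyond the usual scatter. The next structure is compound 3 `CC(C)Oc1ccc(/N=c2\[nH]c(=O)n(C[C@H](C)C(=O)O)c(=O)n2Cc2ccc(Cl)cc2)cc1Cl`, which differs from compound 2 by chloro in place of methyl on an aromatic carbon, so that 4-methylbenzyl becomes 4-chlorobenzyl. Among the compounds with values here, no measured pair shows this change alone, so its size cannot be read directly from the data. Within the data shown here, the only guide is the gap in this measurement between compound 1 at 108% and compound 2 at 73.1%. A modest rise is therefore expected (a number 11.9 percentage points higher from compound 2 to compound 3 (beyond the scatter)), and it may well stay within the scatter. In this assay compound 3 is estimated at 85% with a range from 60% to 110% as the likely span.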

Compound 3, oral bioavailability: 82.4%
Beside the measured number, compound 3's estimate is 2.6 percentage points above it, and the stated range covers the measured number.
By their numbers in this assay, from the lowest: compounds 2 and 3 (each within the scatter of the next); then compound 1.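

In this assay, swapping 4-methylbenzyl for 4-chlorobenzyl gives a number 9.3 percentage points higher from compound 2 to compound 3 (within the scatter), so at this place on the ring, para to a large group, the two groups cannot be told apart by this read-out. The larger step lies elsewhere, at the stereocentre on a saturated chain carbon, with a number 25.6 percentage points lower from compound 1 to compound 3 (beyond the scatter). That step can be assigned to this single centre because nothing else separates the two structures: the fact that compounds 1 and 3 differ only in the configuration as drawn

On these data alone, whether the swap from methyl to chloro would look the same in the R series remains open, since only the S pair shows it. Also open, as far as these compounds go, is whether a different group at this ring carbon, such as an amine or a nitrile, would stay within the scatter of these numbers.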